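The source may hold more compounds than are shown below. What is called first, only, known or untested is meant among the compounds shown, and "the series" means these compounds.

Series notes. Compound 1 `CCc1ccc(-c2nc3c(c(C)nn3-c3ccccc3)c(-c3ccccc3C#N)c2C#N)cc1` holds the lowest of the three measured numbers: in a physicochemical assay for solubility, read by spectrophotometry, in phosphate buffer, with a stated time of 18 h, at pH 7.4 (a higher number here means a more soluble compound, a lower number a less soluble compound), compound 1 gives 2400 nM, while compound 2 `CCc1ccc(-c2nc3c(c(C)nn3-c3ccccc3)c(-c3ccccc3I)c2C#N)cc1` gives 8500 nM and compound 3 `CCc1ccc(-c2nc3c(c(C)nn3-c3ccccc3)c(-c3ccccc3OC)c2C#N)cc1` gives 7800 nM. Compound 4 `CCc1ccc(-c2nc3c(c(C)nn3-c3ccccc3)c(-c3cccc(O)c3)c2C#N)cc1` is not yet measured; it differs from compound 1 by 3-hydroxyphenyl in place of 2-cyanophenyl on an aromatic carbon. The two measured steps that replace the cyano group on that phenyl ring bear on this: a 3.5-fold higher number from compound 1 to compound 2 (0.55 log units; beyond the scatter) and a 3.3-fold higher number from compound 1 to compound 3 (0.51 log units; beyond the scatter), each a modest rise. The change to compound 4 also removes that cyano group, though what enters differs from either measured case. A modest rise beyond the scatter is therefore expected, a 2.9-fold higher number from compound 1 to compound 4 (0.46 log units; beyond the scatter). For compound 4 the estimated value is 7000 nM, with a range from 3000 nM to 18000 nM.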

Compound 4, solubility: 18000 nM
Compound 4: the middle estimate sits 2.6-fold (0.41 log units) below what was measured; the measured number falls inside the stated range.
By their numbers in this assay, from the lowest: compound 1; then compounds 3 and 2 (each within the scatter of the next); then compound 4.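

In this assay, 3-hydroxyphenyl gives the largest step yet at this aromatic carbon (a 7.5-fold higher number from compound 1 to compound 4 (0.88 log units; beyond the scatter)), and it also stands clear of both other replacements (a 2.3-fold higher number from compound 3 to compound 4 (0.36 log units; beyond the scatter); a 2.1-fold higher number from compound 2 to compound 4 (0.33 log units; beyond the scatter)). Removing 2-cyanophenyl therefore does not fix the outcome, as the entering group still shifts the number, and compound 4 alone among these carries a hydrogen-bond donor. Nothing available explains the rise.

Still open is whether the step follows the hydroxy group itself or where it sits on the phenyl ring, since the compounds shown do not separate the two. A phenyl ring bearing an amine or a carboxylic acid would show whether the rise extends beyond hydroxy.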